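Ethoxycarbonyl in place of chloro: compound 1 to compound 3

The compounds below may be only part of what the source reports. "The series", "measured", "known", "first", "only" and "open" are said of these compounds alone.

In a functional assay on Caco-2 cells (Homo sapiens) for antiproliferative activity, with a stated time of 48 h (a lower number here means a stronger inhibitor, a higher number a weaker inhibitor), compound 1 (`CCN(CC)c1ccc(-c2cccc(Cl)c2)nn1`) reads > 25000 nM as a limit of the assay and not a number. Among the measured compounds shown here, compound 2 (`CCOC(=O)c1ccc(-c2ccc(N(CC)CC)nn2)cc1`) gives 4000 nM in this assay as the only true number so far. Compound 3 (`CCOC(=O)c1cccc(-c2ccc(N(CC)CC)nn2)c1`) differs from compound 1 at one place (ethoxycarbonyl in place of chloro on an aromatic carbon) with ethoxycarbonyl in place of chloro on an aromatic carbon, meta to a large group. For the measured compounds named here, compound 2 at 4000 nM is the only guide to a clear step toward stronger inhibition. The expected step is large but poorly defined (an at least 3.5-fold lower number from compound 1 to compound 3 (0.55 log units; beyond the scatter)). For compound 3 the estimated value is 7000 nM (expected range 2500 nM to 25000 nM).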

Compound 3, half-maximal inhibitory concentration: > 25000 nM
Compound 3 gave a limit, no number; the forecaster's own chance of this, stated with the estimate: 20%; middle value at least 3.5-fold (0.55 log units) from the limit.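

No step can be read between compound 1 and compound 3, since each stands only as a limit of the assay, not a number: the limit of > 25000 nM in this assay, at which 2 of the 3 values shown sit.

As far as these compounds go, whether ethoxycarbonyl in place of chloro on an aromatic carbon changes the read-out at all stays open.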